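The source may report more compounds than this note shows. Statements on the series, on what has been measured and on what is new or still open speak of the compounds shown alone.

Measured in a functional assay on NCI-H1975 cells (Homo sapiens) for antiproliferative activity, read by MTT assay, with a stated time of 72 h (on this read-out higher numbers stand for weaker inhibition and lower numbers for stronger inhibition), so far:
compound 1 `COc1cc2ncnc(Nc3cccc(Cl)c3)c2cc1OCCCCC(=O)Nc1ccc(S(N)(=O)=O)cc1`: 33200 nM
compound 2 `C#Cc1cccc(Nc2ncnc3ccc(NC(=S)Nc4ccc(S(N)(=O)=O)cc4)cc23)c1`: 13400 nM

Of the two numbers in this assay, compound 2 holds the lower one; compound 1 sits above it by a gap beyond the usual scatter. Going by the values given here, no pair of measured compounds differs in just one place, so the series gives no direct precedent for single changes, and the two values carry no more than their own comparison.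

Compound 3 `Cc1ccc(Nc2ncnc3ccc(NC(=S)Nc4ccc(S(N)(=O)=O)cc4)cc23)cc1` awaits measurement in this assay. Relative to compound 2 the change is 4-methylphenyl in place of 3-ethynylphenyl on a nitrogen on an aromatic ring. Without a matched step to lean on, the expectation rests on compound 2 alone and on the change itself. The step from compound 2 to compound 3 in this assay is expected to go upward, toward weaker inhibition, by a margin modestly beyond the scatter, as a 2.2-fold higher number from compound 2 to compound 3 (0.35 log units; beyond the scatter). Compound 3 is accordingly estimated at 30000 nM, with a likely range from 10000 nM to 90000 nM.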

Compound 3, half-maximal inhibitory concentration: 39400 nM
Compound 3: the middle estimate sits 1.3-fold (0.12 log units) below what was measured; the measured number falls inside the stated range.
By their numbers in this assay, from the lowest: compound 2; then compounds 1 and 3 (each within the scatter of the next).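

In this assay the series now has its first matched step: on a nitrogen on an aromatic ring, 4-methylphenyl in place of 3-ethynylphenyl gives a 2.9-fold higher number from compound 2 to compound 3 (0.47 log units; beyond the scatter) and so moves toward weaker inhibition by a modest margin beyond the scatter. This shows that the aryl group at this position can shift the read-out with the rest of the structure held constant, which the earlier pair, differing in more than one place, could not show. Nothing measured here accounts for the shift.

The step changes both the group and its numbered place on the ring, so it cannot separate these two changes. From the compounds shown here alone, a 3-methylphenyl or a 4-ethynylphenyl group would be needed to tell them apart, and how an amine or a carboxylic acid on this ring would read remains open.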